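Shorter fatty ester on a cytidine-like nucleoside

This account rests on a few compounds, and the source may have more. Where it says the series, first, only, none or still open, it means among the compounds named here.

Measured compounds:
compound 1 `CCCCCCCCCCCCCCCCCCCCCC(=O)OC[C@H]1O[C@@H](n2ccc(N)nc2=O)[C@@H](O)[C@@H]1O` gives 0.04 ug/mL in a functional assay on HeLa cells (Homo sapiens) for cytotoxicity, read by cell counting, with a stated time of 48 h; on this read-out higher numbers stand for an effect only at larger amounts of compound and lower numbers for an effect already at smaller amounts
compound 2 `CCCC(=O)OC[C@H]1O[C@@H](n2ccc(N)nc2=O)[C@@H](O)[C@@H]1OC(=O)CCC` gives 0.11 ug/mL in this assay
compound 3 `CCCCCCCCCCCCCC(=O)O[C@H]1[C@H](O)[C@H](n2ccc(N)nc2=O)O[C@@H]1CO` gives 0.08 ug/mL in this assay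

All three are fatty-acid esters of the same nucleoside core, differing in where the ester sits and how long its chain is. Compound 1 has the lowest number of the three in this assay, meaning its effect on the cells appears at the smallest amount. Against compound 3 the gap falls within the scatter, so no order between these two can be claimed. Against compound 2, which carries two short butyryl esters, the gap is beyond the scatter, so compound 2 needs a larger amount for the same effect.

Compound 4 `CCCCCCCCCC(=O)OC[C@H]1O[C@@H](n2ccc(N)nc2=O)[C@@H](O)[C@@H]1O` keeps the single ester on the primary alcohol but shortens its chain: hydrogen in place of dodecyl on a saturated chain carbon, nine bonds along the chain from a carbonyl carbon. Going by the values given here, no measured pair here differs by chain length alone at that position, so the size of this step has to be guessed from the spread of the three values.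

For compound 4 a modest loss is expected, a number somewhat higher than that of compound 1, near the edge of the scatter, giving an estimated step of a 2.0-fold higher number from compound 1 to compound 4 (0.30 log units; within the scatter). The estimate for compound 4 in this assay is 0.08 ug/mL, expected to lie between 0.03 ug/mL and 0.22 ug/mL.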

Compound 4, concentration for half-maximal effect: 0.1 ug/mL
Compound 4: middle estimate off by 1.3-fold (0.10 log units), on the low side, and the stated range covers the measured number.
By their numbers in this assay, from the lowest: compounds 1, 3, 4 and 2 (each within the scatter of the next, the first and the last beyond it).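

Taking dodecyl away and leaving hydrogen on a saturated chain carbon, nine bonds along the chain from a carbonyl carbon, gives in this assay a 2.5-fold higher number from compound 1 to compound 4 (0.40 log units; beyond the scatter) and so provides the first comparison here between two compounds that differ in one place. The change is modest, but it shows that the dodecyl group matters at this place: without it, a larger amount of compound is needed for the same effect on the cells, while the ester on the primary alcohol and the shared core stay the same. Nothing measured here explains this difference.

A single pair gives only two points, so it cannot show whether the number climbs steadily as the chain shortens or changes abruptly at some chain length, and a longer chain could carry the trend further or reverse it. It also leaves open what an amine or a carboxylic acid would do in place of the dodecyl group, on a saturated chain carbon, nine bonds along the chain from a carbonyl carbon.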